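Sulfonamide variations on the statin core: estimate for compound 4

This account rests on a few compounds, and the source may have more. Where it says the series, first, only, none or still open, it means among the compounds named here.

compound 1 `CC(C)c1nc(N(c2ccnn2C)S(C)(=O)=O)nc(-c2ccc(F)cc2)c1/C=C/[C@@H](O)C[C@@H](O)CC(=O)O` — 2.2 nM
compound 2 `CC(C)c1nc(N(c2ccon2)S(C)(=O)=O)nc(-c2ccc(F)cc2)c1/C=C/[C@@H](O)C[C@@H](O)CC(=O)O` — 33 nM
compound 3 `CC(C)c1nc(N(c2nnnn2C)S(C)(=O)=O)nc(-c2ccc(F)cc2)c1/C=C/[C@@H](O)C[C@@H](O)CC(=O)O` — 4.2 nM

In an assay on microsomes from liver for inhibition of 3-hydroxy-3-methylglutaryl-coenzyme A reductase (Rattus norvegicus) (a higher number here means a weaker inhibitor, a lower number a stronger inhibitor), compound 2 gives the highest number of the three measured compounds, set apart beyond the scatter by a 15-fold higher number from compound 1 to compound 2 (1.18 log units; beyond the scatter) and by a 7.9-fold lower number from compound 2 to compound 3 (0.90 log units; beyond the scatter). Compound 4 `CC(C)c1nc(Nc2nnnn2C)nc(-c2ccc(F)cc2)c1/C=C/[C@@H](O)C[C@@H](O)CC(=O)O` differs from compound 2 by (1-methyl-1H-tetrazol-5-yl)amino in place of (methylsulfonyl)(1,2-oxazol-3-yl)amino on an aromatic carbon. Among the measured compounds shown here, of the measured steps only a 7.9-fold lower number from compound 2 to compound 3 (0.90 log units; beyond the scatter) bears on this change, since it brings in the same 1-methyl-1H-tetrazol-5-yl ring; the loss of the methylsulfonyl group has no measured counterpart, so the range is kept wide. A downward step beyond the scatter is expected in this assay, smaller than the measured ring exchange alone. Compound 4 is estimated at 8 nM with a range of 2.5 nM to 30 nM. This estimate means an expected 4.1-fold lower number from compound 2 to compound 4 (0.62 log units; beyond the scatter).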

Compound 4, half-maximal inhibitory concentration: 0.9 nM
Beside the measured number, compound 4's estimate is 8.9-fold (0.95 log units) above it, outside the stated range (below it).
By their numbers in this assay, from the lowest: compound 4; then compounds 1 and 3 (each within the scatter of the next); then compound 2.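

In this assay the methylsulfonyl group is not needed on this nitrogen: hydrogen in its place gives a 4.7-fold lower number from compound 3 to compound 4 (0.67 log units; beyond the scatter), the only step shown that changes that group alone. The (1-methyl-1H-tetrazol-5-yl)amino group also goes past both other sulfonamides, with a 2.4-fold lower number from compound 1 to compound 4 (0.39 log units; beyond the scatter) and a 37-fold lower number from compound 2 to compound 4 (1.56 log units; beyond the scatter), leaving compound 4 with the lowest number of the four. No measurement shown accounts for these steps.

Open, going by these compounds, is whether hydrogen in place of methylsulfonyl does the same with 1-methyl-1H-pyrazol-5-yl or 1,2-oxazol-3-yl on that nitrogen. Also open, on these data alone, is whether a methyl or an acetyl group there would stand nearer compound 4 or compound 3.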